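Ketone substituent changes in one cytotoxicity series

The source may hold more compounds than are shown below. What is called first, only, known or untested is meant among the compounds shown, and "the series" means these compounds.

Measured so far:
compound 1 `COc1cc(-c2nnc3n2NC(c2ccco2)C(C(=O)c2ccc(Cl)cc2)S3)cc(OC)c1OC` gives 67800 nM
compound 2 `COc1cc(-c2nnc3n2NC(c2ccco2)C(C(=O)C2CC2)S3)cc(OC)c1OC` gives 95200 nM
compound 3 `COc1cc(-c2nnc3n2NC(c2ccco2)C(C(=O)c2ccccc2)S3)cc(OC)c1OC` gives 64300 nM

All three numbers come from a functional assay on PC-3 cells (Homo sapiens) for cytotoxicity, read by MTT assay, with a stated time of 48 h; a higher number here means a weaker inhibitor, a lower number a stronger inhibitor. Compound 3 has the lowest number of the three, but its steps to the others are small: a 1.1-fold lower number from compound 1 to compound 3 (0.02 log units; within the scatter) and a 1.5-fold lower number from compound 2 to compound 3 (0.17 log units; within the scatter). The third step, a 1.4-fold higher number from compound 1 to compound 2 (0.15 log units; within the scatter), is likewise within the scatter, so the three compounds cannot be ordered on these data.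

Compound 4 `COc1cc(-c2nnc3n2NC(c2ccco2)C(C(=O)c2ccc(F)c(F)c2)S3)cc(OC)c1OC` carries the change (3,4-difluorophenyl in place of phenyl on a carbonyl carbon). The step that bears most directly on it is the halogen change on the same ring, a 1.1-fold lower number from compound 1 to compound 3 (0.02 log units; within the scatter), which was within the scatter. Replacing the whole group on the carbonyl carbon, as in a 1.4-fold higher number from compound 1 to compound 2 (0.15 log units; within the scatter) and a 1.5-fold lower number from compound 2 to compound 3 (0.17 log units; within the scatter), also moved the number no further than the scatter. Hence no step beyond the scatter is expected for compound 4 in this assay, and the expected step is a 1.0-fold higher number from compound 3 to compound 4 (0.00 log units; within the scatter). Compound 4 is estimated at 65000 nM, with a range from 30000 nM to 140000 nM.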

Compound 4, half-maximal inhibitory concentration: 36000 nM
Compound 4: middle estimate off by 1.8-fold (0.26 log units), on the high side, within the range that was stated.
By their numbers in this assay, from the lowest: compounds 4, 3, 1 and 2 (each within the scatter of the next, the first and the last beyond it).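

In this assay, among the compounds shown here, the change to 3,4-difluorophenyl on the carbonyl carbon gives the only step in this set that lies beyond the scatter, and a modest one: a 2.6-fold lower number from compound 2 to compound 4 (0.42 log units; beyond the scatter). Against the other aryl ketones the same group stays within the scatter, with a 1.8-fold lower number from compound 3 to compound 4 (0.25 log units; within the scatter) and a 1.9-fold lower number from compound 1 to compound 4 (0.27 log units; within the scatter), so phenyl, 4-chlorophenyl and 3,4-difluorophenyl cannot be separated at this position, and only cyclopropyl and 3,4-difluorophenyl are told apart. No measurement at hand accounts for this step.

The compounds shown leave open how a morpholine, a carboxylic acid or a longer alkyl chain in place of the aryl group on the carbonyl carbon would read in this assay. They also leave open whether a single fluorine, as in 4-fluorophenyl, would read like 3,4-difluorophenyl.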